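Swapping Dimethylamino for Diethylamino on the Side Chain

A few compounds are considered here, and "the series" means these few. Any claim that something is new, unique, unknown or untested is made for them only; others in the source may bear on it.

Of the compounds shown here, three sharing one core have been measured in a functional assay on MKN-45 cells (Homo sapiens) for cytotoxicity, read by MTT assay, with a stated time of 72 h; a higher number here means a weaker inhibitor, a lower number a stronger inhibitor. Compound 1 `CN(C)CCCNc1nc(-c2ccc(NC(=O)Nc3ccc(F)cc3)cc2)nc2c(Cl)c(Cl)sc12` gives 1120 nM. Compound 2 `CN(C)CCCNc1nc(-c2ccc(NC(=O)Nc3ccc(Cl)cc3)cc2)nc2c(Cl)c(Cl)sc12` gives 1530 nM, the second highest of the three numbers. Compound 3 `CN(C)CCCNc1nc(-c2ccc(NC(=O)Nc3ccc(Cl)cc3Cl)cc2)nc2c(Cl)c(Cl)sc12` gives 2560 nM. The measured steps all lie on the ring attached to the urea: a 1.4-fold higher number from compound 1 to compound 2 (0.14 log units; within the scatter), a 1.7-fold higher number from compound 2 to compound 3 (0.22 log units; within the scatter), and a 2.3-fold higher number from compound 1 to compound 3 (0.36 log units; beyond the scatter).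

Compound 4 `CCN(CC)CCCNc1nc(-c2ccc(NC(=O)Nc3ccc(Cl)cc3)cc2)nc2c(Cl)c(Cl)sc12` differs from compound 2 elsewhere: diethylamino in place of dimethylamino on a saturated chain carbon, three bonds along the chain from a nitrogen on an aromatic ring. Within the data shown here, none of the measured steps touches this side chain, so the three measured compounds give no direct evidence about this change. With nothing pointing in either direction, the expectation is that compound 4 stays close to compound 2. The expected step is a 1.0-fold lower number from compound 2 to compound 4 (0.01 log units; within the scatter), that is, nothing beyond the scatter. Compound 4 is therefore estimated to give about 1500 nM in this assay, with a range from 500 nM to 4500 nM.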

Compound 4, half-maximal inhibitory concentration: 720 nM
Compound 4: middle estimate off by 2.1-fold (0.32 log units), on the high side; low and high end bracket the measured number.
By their numbers in this assay, from the lowest: compounds 4, 1, 2 and 3 (each within the scatter of the next, the first and the last beyond it).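

The side chain is not a silent position: in this assay, diethylamino in place of dimethylamino gives a 2.1-fold lower number from compound 2 to compound 4 (0.33 log units; beyond the scatter) and so a modest gain in potency that goes beyond the scatter. Among these compounds, the only earlier step beyond the scatter, a 2.3-fold higher number from compound 1 to compound 3 (0.36 log units; beyond the scatter) on the ring attached to the urea, ran the opposite way, so this is the first sign of a change that yields a stronger inhibitor. No evidence is available that explains this step, which rests on a single pair of compounds.

On these data alone, it remains open whether the same swap would give a similar step with the 4-fluorophenyl of compound 1 or the 2,4-dichlorophenyl of compound 3. Also open, as far as these compounds go, is how the number would respond to a dipropylamino group, a pyrrolidine ring or a longer chain at this end.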